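A few compounds are considered here, and "the series" means these few. Any claim that something is new, unique, unknown or untested is made for them only; others in the source may bear on it.

Measured compounds in a functional assay on MCF7 cells (Homo sapiens) for inhibition; a higher number here means a weaker inhibitor, a lower number a stronger inhibitor:
- compound 1, `CC/C(=C(/c1ccc(/C=C/C(=O)O)cc1)c1cc2ccccc2[nH]1)c1ccccc1C`, gives 33 nM
- compound 2, `CC/C(=C(/c1ccc(/C=C/C(=O)O)cc1)c1cc2ccccc2[nH]1)c1cccc(OC(F)(F)F)c1`, gives 282 nM
- compound 3, `CC/C(=C(/c1ccc(/C=C/C(=O)O)cc1)c1cc2ccccc2[nH]1)c1ccc(C(F)(F)F)cc1Cl`, gives 27 nM

All three share one core and differ only in the aromatic ring attached to a double-bonded chain carbon bound to a double-bonded chain carbon and a saturated chain carbon. Compound 1 sits second highest of the three numbers; compound 3 is within the scatter of it, as a 1.2-fold lower number from compound 1 to compound 3 (0.09 log units; within the scatter) shows, while compound 2 is clearly weaker, as an 8.5-fold higher number from compound 1 to compound 2 (0.93 log units; beyond the scatter) shows. Compound 4, `CC/C(=C(/c1ccc(/C=C/C(=O)O)cc1)c1cc2ccccc2[nH]1)c1ccc(Cl)cc1C#N`, is the next variation on this ring: 4-chloro-2-cyanophenyl in place of 2-methylphenyl on a double-bonded chain carbon bound to a double-bonded chain carbon and a saturated chain carbon. Both earlier steps from compound 1 bear on this change, since each swaps the same ring for another substituted ring; one left the number essentially unchanged and the other raised it modestly. The entering 4-chloro-2-cyanophenyl ring, like the 2-chloro-4-(trifluoromethyl)phenyl of compound 3, carries a chlorine, so a small step is expected in this assay, at most a slight rise: a 1.4-fold higher number from compound 1 to compound 4 (0.13 log units; within the scatter). Compound 4 is therefore estimated at 45 nM, with a range from 15 nM to 140 nM.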

Compound 4, half-maximal inhibitory concentration: 14 nM
For compound 4 the middle estimate is 3.2-fold (0.51 log units) above the measured one; the measured number lies below the stated range.
By their numbers in this assay, from the lowest: compounds 4, 3 and 1 (each within the scatter of the next, the first and the last beyond it); then compound 2.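

In this assay this position gives, for the first time among these compounds, a replacement for the 2-methylphenyl of compound 1 that yields a stronger inhibitor by more than the scatter (a 2.4-fold lower number from compound 1 to compound 4 (0.37 log units; beyond the scatter)). Compound 4 stays within the scatter of the other chlorine-bearing ring (a 1.9-fold lower number from compound 3 to compound 4 (0.29 log units; within the scatter)), and the distance to the 3-(trifluoromethoxy)phenyl ring is large (a 20-fold lower number from compound 2 to compound 4 (1.30 log units; beyond the scatter)), although compound 1, which has no chlorine, goes against any simple link between chlorine and a low number. No measurement shown explains this result.

Going by these compounds, the nitrile and the chlorine enter together, so the share of each in this step stays open. On these data alone, how a ring carrying an amine or a carboxylic acid would behave at this position also stays open.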